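The compounds below may be only part of what the source reports. "The series", "measured", "known", "first", "only" and "open" are said of these compounds alone.

Measured compounds in a functional assay on PC-3 cells (Homo sapiens) for cytotoxicity, read by MTT assay, with a stated time of 72 h; on this read-out higher numbers stand for weaker inhibition and lower numbers for stronger inhibition:
- compound 1 `CCCOCNc1n[n+]([O-])c2cc(OC)ccc2[n+]1[O-]`: 10600 nM
- compound 2 `CCCCOCNc1n[n+]([O-])c2ccccc2[n+]1[O-]`: 6010 nM
- compound 3 `CCCOCNc1n[n+]([O-])c2ccccc2[n+]1[O-]`: 7400 nM

Compound 3 gives the second highest of the three numbers in this assay. Its nearest neighbour is compound 2, and the step of a 1.2-fold higher number from compound 2 to compound 3 (0.09 log units; within the scatter) is within the scatter. The step of a 1.4-fold lower number from compound 1 to compound 3 (0.16 log units; within the scatter) is likewise within the scatter, so the three compounds are not separated on this read-out.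

Compound 4 `CCCCCOCNc1n[n+]([O-])c2ccccc2[n+]1[O-]` has not been measured. Against compound 3 the change is ethyl in place of hydrogen on a saturated chain carbon, three bonds along the chain from an oxygen on a saturated carbon. Among the compounds with values here, the one measured step that bears on it is the chain change from compound 2 to compound 3, where the shorter chain in compound 3 gave a 1.2-fold higher number from compound 2 to compound 3 (0.09 log units; within the scatter), a difference that does not rise above the scatter. Extending the same chain further, by the ethyl named above, is therefore expected to move the number little, if at all, in this assay; the direction, if any, is taken from compound 2 and leans toward a lower number.

The estimated step is a 1.3-fold lower number from compound 3 to compound 4 (0.13 log units; within the scatter), giving an expected value for compound 4 of 5500 nM, with the range 2500 nM to 12000 nM.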

Compound 4, half-maximal inhibitory concentration: 8510 nM
For compound 4 the middle estimate is 1.5-fold (0.19 log units) below the measured one; measured number inside the range.
By their numbers in this assay, from the lowest: compounds 2, 3, 4 and 1 (each within the scatter of the next).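

In this assay there is a 1.2-fold higher number from compound 3 to compound 4 (0.06 log units; within the scatter) and a 1.4-fold higher number from compound 2 to compound 4 (0.15 log units; within the scatter) for the longer chain of compound 4. Both steps lie within the scatter, so the read-out does not separate the chains of compound 2, compound 3 and compound 4, and this position has so far shown no dependence on chain length in this assay. No supporting measurement is available to explain this result.

Going by these compounds, whether this position tolerates any change at all remains open, since a longer chain, or an amine or a carboxylic acid at the end of the chain, could still separate from these compounds. It is also open whether a chlorine on an aromatic carbon of the shared core would move the number, given that the only such change shown, methoxy to hydrogen, stays within the scatter.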